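Chain shortening on the isopropyl member of the series

The source may report more compounds than this note shows. Statements on the series, on what has been measured and on what is new or still open speak of the compounds shown alone.

Measured so far in a functional assay on HL-60 cells (Homo sapiens) for cytotoxicity, read by MTT assay, with a stated time of 48 h; on this read-out higher numbers stand for weaker inhibition and lower numbers for stronger inhibition:
compound 1, `CCCCCCCCCCCCCCCCCC(=O)N[C@@H](CCSC)C(=O)Nc1ccn([C@H]2O[C@@H](CO)[C@H](O)[C@H]2O)c(=O)n1`, gives 803 nM
compound 2, `CCCCCCCCCCCCCC(=O)N[C@@H](CCCNC(=N)N)C(=O)Nc1ccn([C@H]2O[C@@H](CO)[C@H](O)[C@H]2O)c(=O)n1`, gives 405 nM
compound 3, `CCCCCCCCCCCCCCCCCC(=O)N[C@H](C(=O)Nc1ccn([C@H]2O[C@@H](CO)[C@H](O)[C@H]2O)c(=O)n1)C(C)C`, gives 31900 nM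

Compound 3 stands at the highest number of the three in this assay; its nearest neighbour is compound 1, at a far lower number, and compound 2 is further still. For the measured compounds named here, the only single-place step available, a 40-fold higher number from compound 1 to compound 3 (1.60 log units; beyond the scatter), concerns the side chain on the saturated chain carbon bound to an amide-type nitrogen and a carbonyl carbon, not the long acyl chain.

Compound 4, `CCCCCCCCCCCCCC(=O)N[C@H](C(=O)Nc1ccn([C@H]2O[C@@H](CO)[C@H](O)[C@H]2O)c(=O)n1)C(C)C`, differs from compound 3 by hydrogen in place of butyl on a saturated chain carbon, ten or more bonds along the chain from a carbonyl carbon. Going by the values given here, no measured step addresses this change alone. Compound 2 carries the same shorter acyl chain as compound 4, but it also differs from compound 1 in the side chain, so its value shows a combined effect only and cannot be split. With nothing that bears directly on the acyl chain, the working expectation for compound 4 is a step in this assay near the scatter, without a firm direction, so a 1.3-fold lower number from compound 3 to compound 4 (0.11 log units; within the scatter) is the expected step. Compound 4 is therefore estimated at 25000 nM, within 8000 nM to 80000 nM.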

Compound 4, half-maximal inhibitory concentration: 32300 nM
Compound 4: the middle estimate sits 1.3-fold (0.11 log units) below what was measured; the range from low to high includes it.
By their numbers in this assay, from the lowest: compounds 2 and 1 (each within the scatter of the next); then compounds 3 and 4 (each within the scatter of the next).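

In this assay, for the compounds shown here, a 1.0-fold higher number from compound 3 to compound 4 (0.01 log units; within the scatter) gives the first direct reading on the acyl chain: with the isopropyl side chain held constant, hydrogen in place of butyl on that chain stays within the scatter. At the shorter acyl length, an 80-fold higher number from compound 2 to compound 4 (1.90 log units; beyond the scatter) shows a large step for a group of 3 heavy atoms in place of a group of 7 heavy atoms on the saturated chain carbon bound to an amide-type nitrogen and a carbonyl carbon, so among these compounds the large steps, including a 40-fold higher number from compound 1 to compound 3 (1.60 log units; beyond the scatter), all lie at that carbon and the one acyl step does not. No supporting data explain this difference between the two positions.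

The compounds shown leave open whether hydrogen in place of butyl would stay as flat with the 2-(methylsulfanyl)ethyl side chain or the arginine-type side chain of compound 2, as neither side chain is seen here at both acyl lengths. Going by these compounds, how a much longer acyl chain, or an amine or a carboxylic acid on the side chain, would read in this assay also remains open.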